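Swapping 3,4-Dimethoxyphenyl for 2,3-Dimethoxyphenyl on the Carbonyl Carbon

A few compounds are considered here, and "the series" means these few. Any claim that something is new, unique, unknown or untested is made for them only; others in the source may bear on it.

Three amides sharing one core have been tested in a functional assay on MDA-MB-231 cells (Homo sapiens), read by microscopy and transwell migration, with a stated time of 24 h; a higher number here means a weaker inhibitor, a lower number a stronger inhibitor. Compound 1 `COc1cc(-c2csc(NC(=O)c3ccccc3)n2)cc(OC)c1OC` gives > 50000 nM, which is a limit and not a number. Compound 2 `COc1cc(-c2csc(NC(=O)c3ccc(Cl)cc3)n2)cc(OC)c1OC` gives > 25000 nM, also a limit. As far as these compounds go, compound 3 `COc1ccc(C(=O)Nc2nc(-c3cc(OC)c(OC)c(OC)c3)cs2)cc1OC` gives > 25000 nM, again only a limit, so its true position is unknown.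

Compound 4 `COc1cc(-c2csc(NC(=O)c3cccc(OC)c3OC)n2)cc(OC)c1OC` has the same atoms as compound 3, joined differently: 2,3-dimethoxyphenyl in place of 3,4-dimethoxyphenyl on a carbonyl carbon. In words, 2,3-dimethoxyphenyl stands in place of 3,4-dimethoxyphenyl on a carbonyl carbon.

Three measured steps change the group at this same place: a step that the two limits leave unreadable from compound 1 to compound 2, a step that the two limits leave unreadable from compound 1 to compound 3 and a step that the two limits leave unreadable from compound 2 to compound 3. None of them has a readable size, so they offer no direction to carry over.

With compound 3 resting on the limit of > 25000 nM, no step beyond the scatter is expected in this assay. The estimated change is a number no higher from compound 3 to compound 4 (the limit leaves the size open). For compound 4 the expected value is 25000 nM, with an estimated range of 8000 nM to 50000 nM.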

Compound 4, half-maximal inhibitory concentration: 15000 nM
Beside the measured number, compound 4's estimate is 1.7-fold (0.22 log units) above it; the range from low to high includes it.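

Among these compounds, compound 4 is the only one of these four amides with a measured number in this assay, so a readable value now exists for this place on the carbonyl carbon, from a group with the same atoms as the one in compound 3, joined differently. Two of the new steps have floors that do not clear the usual scatter: an at least 1.6-fold lower number from compound 3 to compound 4 (0.22 log units; that floor lies within the scatter) and an at least 1.6-fold lower number from compound 2 to compound 4 (0.22 log units; that floor lies within the scatter). Only an at least 3.3-fold lower number from compound 1 to compound 4 (0.52 log units; beyond the scatter) is a step beyond the scatter, which gives this place its first readable change.

As far as these compounds go, the true size of all three steps stays open, because the other compounds give only limits: the limit of > 25000 nM in this assay, at which 2 of the 4 values shown sit. Also open is what an amine or a carboxylic acid would give in place of the dimethoxyphenyl group on the carbonyl carbon.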